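Swapping Hydroxy and Methoxy Positions on Compound 4

The source may report more compounds than this note shows. Statements on the series, on what has been measured and on what is new or still open speak of the compounds shown alone.

Compound 1 `CN(C)CCn1cnnc1-c1cc(Oc2ccc(NC(=O)N/N=C/c3cccc(O)c3)cc2F)ccn1` gives > 100000 nM in a functional assay on U-87MG ATCC cells (Homo sapiens) for cytotoxicity, read by MTT assay, with a stated time of 72 h (a lower number here means a stronger inhibitor, a higher number a weaker inhibitor), which is a limit of the assay rather than a number. Compound 2 `CN(C)CCn1cnnc1-c1cc(Oc2ccc(NC(=O)N/N=C/c3ccc(F)cc3Cl)cc2F)ccn1` gives 1210 nM in this assay. Compound 3 `COc1ccc(/C=N/NC(=O)Nc2ccc(Oc3ccnc(-c4nncn4CCN(C)C)c3)c(F)c2)cc1O` gives > 100000 nM in this assay, again a limit rather than a number.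

Compound 3 therefore stands at the weak end of what has been seen: the step of an at least 82-fold higher number from compound 2 to compound 3 (1.91 log units; beyond the scatter) is large, while the step that the two limits leave unreadable from compound 1 to compound 3 cannot be read because both ends are limits, as noted in the limit of > 100000 nM in this assay, at which 2 of the 3 values shown sit. Compound 4 `COc1cc(/C=N/NC(=O)Nc2ccc(Oc3ccnc(-c4nncn4CCN(C)C)c3)c(F)c2)ccc1O` differs from compound 3 only in 4-hydroxy-3-methoxyphenyl in place of 3-hydroxy-4-methoxyphenyl on a carbon with a double bond to nitrogen. Going by the values given here, no measured step tests such a positional swap directly; the only large step, an at least 82-fold lower number from compound 1 to compound 2 (1.91 log units; beyond the scatter), replaced the hydroxy-bearing ring with a halogenated one, which is not what happens here. With the same atoms rearranged on the same ring, the expected step of a number no higher from compound 3 to compound 4 (the limit leaves the size open) is small, and compound 4 is estimated at 100000 nM, within 20000 nM to 300000 nM, most likely reported as a limit once more.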

Compound 4, half-maximal inhibitory concentration: > 100000 nM
Compound 4 ended at the assay's limit (the forecaster's own chance of this, stated with the estimate: 75%); the middle value sits exactly at the limit.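

Rearranging the hydroxy and methoxy groups on this ring brings no measurable activity into view in this assay: compound 4, with its 4-hydroxy-3-methoxyphenyl, gives > 100000 nM, which is a limit of the assay and not a number. The new ring also falls short of the halogenated ring of compound 2, with an at least 82-fold higher number from compound 2 to compound 4 (1.91 log units; beyond the scatter). The steps to compound 4 from compound 1 and from compound 3 cannot be read, since both ends of each are limits, and that leaves this position as follows: the limit of > 100000 nM in this assay, at which 3 of the 4 values shown sit.

How compound 1, compound 3 and compound 4 truly rank remains hidden, as does any effect of the swap itself. Also open, from the compounds shown here alone, is how this position would respond to a ring carrying only a chlorine, or to an amine or a carboxylic acid in place of the hydroxy group.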